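Methoxy in place of the isothiourea-like group on the outer ring

A few compounds are considered here, and "the series" means these few. Any claim that something is new, unique, unknown or untested is made for them only; others in the source may bear on it.

Compound 2 `CC1(C)N=C(N)N=C(N)N1c1cccc(COc2cccc(NC(=N)S)c2)c1` gives 8.08 in a functional assay on L5178Y cells (Mus musculus) for inhibition; a higher number here means a more potent compound, by a factor of ten per unit of this negative logarithm, a lower number a less potent compound; compound 1 `CC(C)c1cccc(OCc2cccc(N3C(N)=NC(N)=NC3(C)C)c2)c1` gives 8.13, and the two lie within the scatter of each other, so neither can be ranked above the other. Compound 3 `COc1cccc(OCc2cccc(N3C(N)=NC(N)=NC3(C)C)c2)c1` carries the change (a group of 2 heavy atoms (1 carbon, 1 oxygen; no ring) in place of a group of 4 heavy atoms (1 carbon, 2 nitrogen, 1 sulfur; no ring), on an aromatic carbon). Within the data shown here, the only step that bears on this position is a number 0.05 log units lower from compound 1 to compound 2 (within the scatter), which shows the value tolerating a very different group there. A step of a number 0.18 log units lower from compound 2 to compound 3 (within the scatter) is therefore expected, at most modest and not clearly beyond the scatter. For compound 3 the estimate is 7.9, with a range from 7.3 to 8.5.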

Compound 3, logarithm of the reciprocal of the active concentration, log(1/C): 8.02
For compound 3 the middle estimate is 0.12 log units below the measured one; measured number inside the range.
By their numbers in this assay, from the lowest: compounds 3, 2 and 1 (each within the scatter of the next).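

In this assay, methoxy on this aromatic carbon gives no readable difference from either earlier group (a number 0.06 log units lower from compound 2 to compound 3 (within the scatter); a number 0.11 log units lower from compound 1 to compound 3 (within the scatter)), and the three compounds cannot be ranked. The position thus tolerates a third group, now a smaller one with no hydrogen-bond donors, extending what the first pair showed. Nothing available explains this tolerance. The compounds shown leave open whether an amine or a carboxylic acid on this carbon would stay in the same range, and whether a longer chain, such as butoxy, would.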